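The source may report more compounds than this note shows. Statements on the series, on what has been measured and on what is new or still open speak of the compounds shown alone.

Compound 1 `O=C(NCc1ccccc1)c1nc(Cc2ccccc2C(F)(F)F)[nH]c(=O)c1O`: > 100000 nM
Compound 2 `CC(c1ccccc1C(F)(F)F)c1nc(C(=O)NCc2ccccc2)c(O)c(=O)n1C`: > 100000 nM
Compound 3 `Cn1c(Cc2ccccc2C(F)(F)F)nc(C(=O)NCc2ccccc2F)c(O)c1=O`: > 100000 nM

Of the compounds shown here, three have been read in an ADME assay on HepG2 cells (Homo sapiens) for cytotoxicity, in the presence of a further agent that is not named here (on this read-out higher numbers stand for weaker inhibition and lower numbers for stronger inhibition), and none of them has yielded a number. In this assay compound 3 gives > 100000 nM, which is a limit of the assay and not a measured value. The series as a whole shows (the limit of > 100000 nM in this assay, at which 3 of the 3 values shown sit), so compound 3 stands with the other two and no order among them can be drawn.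

Compound 4 `Cn1c(Cc2ccccc2C(F)(F)F)nc(C(=O)NCc2ccccc2)c(O)c1=O` is still to be measured. It departs from compound 3 in one place, with hydrogen in place of fluoro on an aromatic carbon, ortho to a large group (hydrogen in place of fluoro on an aromatic carbon). The 2-fluorobenzyl group thus becomes benzyl. Among the measured compounds shown here, no measured pair shows this change directly. The benzylamino group itself is not new to the series, however, as compound 2 carries it. Compound 2 gives > 100000 nM, again a limit.

On that basis, no step beyond the scatter is expected in this assay, and neither direction is favoured. The estimated change is a number no higher from compound 3 to compound 4 (the limit leaves the size open). The assay will most likely report only a limit once more. For compound 4 the expected value is 100000 nM, with an estimated range of 50000 nM to 200000 nM.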

Compound 4, half-maximal inhibitory concentration: > 100000 nM
Compound 4 gave a limit, no number (the forecaster's own chance of this, stated with the estimate: 90%); the middle value lies on the limit itself.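

In this assay compound 4 gives > 100000 nM, which is a limit of the assay and not a measured value. The steps joining compound 4 to compound 1, compound 2 and compound 3 therefore cannot be read, and the series shows only this: the limit of > 100000 nM in this assay, at which 4 of the 4 values shown sit.

The compounds shown leave open whether any of these single changes alters the read-out in this assay at all.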